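The source may hold more compounds than are shown below. What is called first, only, known or untested is meant among the compounds shown, and "the series" means these compounds.

Within the data shown here, compound 1 (`CCCCCOc1ccc2oc(/C=C/[S+](C)[O-])cc(=O)c2c1`) gives 6600 nM in a functional assay on DLD-1 cells (Homo sapiens) for cytotoxicity, with a stated time of 48 h (on this read-out lower numbers stand for stronger inhibition and higher numbers for weaker inhibition), and is one of only two compounds with a number so far. The other, compound 2 (`Cc1cccc2c(=O)cc(/C=C/[S+](C)[O-])oc12`), gives 6800 nM in this assay too, so the two numbers lie within the usual scatter of each other and neither compound can be called the stronger. Among the measured compounds shown here, compound 1 therefore stands level with the only comparison available.

Compound 3 (`Cc1ccc2oc(/C=C/[S+](C)[O-])cc(=O)c2c1`) has not been measured yet. It differs from compound 1 in one place, with methyl in place of pentyloxy on an aromatic carbon of a six-membered aromatic ring of carbon only (methyl in place of pentyloxy on an aromatic carbon). For the measured compounds named here, no measured pair shows what a change of this kind does in this assay on its own, so any forecast here is loose. The two numbers in hand sit level and point in neither direction, so the expectation is no step beyond the scatter. The expected step of a 1.1-fold higher number from compound 1 to compound 3 (0.03 log units; within the scatter) is an estimate and stays small. For compound 3 the estimate is 7000 nM with an expected range from 3000 nM to 16000 nM in this measurement.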

Compound 3, half-maximal inhibitory concentration: 7000 nM
Compound 3: middle estimate and measured number agree at the digits printed; the range from low to high includes it.
By their numbers in this assay, from the lowest: compounds 1, 2 and 3 (each within the scatter of the next).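

Swapping pentyloxy for methyl on this aromatic carbon gives a 1.1-fold higher number from compound 1 to compound 3 (0.03 log units; within the scatter) in this assay, and this is the only step shown so far in which just one group changes. Until now, the two measured compounds could not be compared in this way, so their similar numbers said nothing about this position. The step shows that a chain of 6 heavy atoms with 1 hydrogen-bond acceptor and a methyl of 1 heavy atom with none give numbers within the scatter of each other, so on this pair the size of the group at this position makes no measurable difference; nothing in the data explains this.

Going by these compounds, with only these two groups at this position, it remains open whether an amine or a carboxylic acid on the same aromatic carbon would move the number beyond the scatter, or whether a bare hydrogen there would do so. Also open, on these data alone, is whether the same swap would stay this small if the side chain on the shared core were different.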